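The source may report more compounds than this note shows. Statements on the series, on what has been measured and on what is new or still open speak of the compounds shown alone.

Measured so far in a functional assay on SGC-7901 cells (Homo sapiens) for inhibition, read by MTT assay, with a stated time of 72 h; on this read-out higher numbers stand for weaker inhibition and lower numbers for stronger inhibition:
- compound 1 `O=C(NCc1ccc(NC(=O)c2ccc(F)cc2N2CCCC2)cc1)OCc1cccnc1`: 56200 nM
- compound 2 `O=C(NCc1ccc(NC(=O)c2cc(C(F)(F)F)ccc2N2CCCC2)cc1)OCc1cccnc1`: > 100000 nM (a limit)

For the measured compounds named here, compound 1 carries the only actual number, 56200 nM in this assay. Compound 2 reads > 100000 nM, which is a limit of the assay and not a number. Going by the values given here, the two values therefore give no measured step to work from.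

Next in line is compound 3 `Cc1ccc(C(=O)Nc2ccc(CNC(=O)OCc3cccnc3)cc2)c(N2CCCC2)c1`, which differs from compound 1 by methyl in place of fluoro on an aromatic carbon, meta to a pyrrolidin-1-yl group and para to a large group (methyl in place of fluoro on an aromatic carbon). Among the compounds with values here, no measured pair covers this exchange, so no shift beyond the usual scatter is expected in this assay. The estimated step of a 1.1-fold higher number from compound 1 to compound 3 (0.03 log units; within the scatter) is expected to have no clear direction. Compound 3 is estimated at 60000 nM, with an expected range of 28000 nM to 100000 nM.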

Compound 3, half-maximal inhibitory concentration: 75200 nM
Compound 3: middle estimate off by 1.3-fold (0.10 log units), on the low side; the measured number falls inside the stated range.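

In this assay, for the compounds shown here, the change from fluoro to methyl on this aromatic carbon, meta to a pyrrolidin-1-yl group and para to a large group, gives the first readable step: a 1.3-fold higher number from compound 1 to compound 3 (0.13 log units; within the scatter) and so no shift that stands out from repeat measurements. At this position, these two groups of one heavy atom each are not told apart on this read-out. Going by these compounds alone, compound 2 stays a limit and not a number, and gives no step: the limit of > 100000 nM in this assay, at which 1 of the 3 values shown sits.

As far as these compounds go, whether an amine, a carboxylic acid or a longer chain such as propyl on this carbon would move the number beyond the scatter stays open. From the compounds shown here alone, with the pyrrolidin-1-yl group the same in all three compounds, its part in these values also stays open.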